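Adding a Second Chlorine on the Outer Phenyl Ring

The compounds below may be only part of what the source reports. "The series", "measured", "known", "first", "only" and "open" are said of these compounds alone.

For the measured compounds named here, compound 3 `N[C@@H](COP(=O)(O)OCCCOC(=O)CCc1ccccc1OCc1cccc(Oc2ccccc2Cl)c1)C(=O)O` gives 19.8% in an assay on cells for agonist activity at probable G-protein coupled receptor 34 (Mus musculus), with a stated time of 1 h; a lower number here means a smaller maximal response, a higher number a larger maximal response; of the three numbers so far its nearest neighbour is compound 1 and its furthest compound 2, and both gaps lie within the scatter. Compound 1 `Cc1ccccc1Oc1cccc(COc2ccccc2CCC(=O)OCCCOP(=O)(O)OC[C@H](N)C(=O)O)c1` gives 20.3%, and compound 2 `Cc1ccc(Oc2cccc(COc3ccccc3CCC(=O)OCCCOP(=O)(O)OC[C@H](N)C(=O)O)c2)cc1` gives 18.2%. The step of a number 0.5 percentage points lower from compound 1 to compound 3 (within the scatter) and the step of a number 1.6 percentage points higher from compound 2 to compound 3 (within the scatter) show that changes on this outer phenyl ring have so far left the maximal response where it was. Compound 4 `N[C@@H](COP(=O)(O)OCCCOC(=O)CCc1ccccc1OCc1cccc(Oc2ccc(Cl)c(Cl)c2)c1)C(=O)O` differs from compound 3 by 3,4-dichlorophenyl in place of 2-chlorophenyl on an oxygen on an aromatic ring. Because a number 1.6 percentage points higher from compound 2 to compound 3 (within the scatter) and a number 0.5 percentage points lower from compound 1 to compound 3 (within the scatter) both stayed within the scatter, no shift beyond the scatter is expected: the estimated step is a number 0.2 percentage points higher from compound 3 to compound 4 (within the scatter), and compound 4 is expected to give 20%, within 13% to 27%.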

Compound 4, largest response reached (Emax), in percent of the reference or control that the assay uses: 18%
Estimate against measurement, compound 4: 2 percentage points above, and the stated range covers the measured number.
By their numbers in this assay, from the lowest: compounds 4, 2, 3 and 1 (each within the scatter of the next).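

In this assay a second chlorine on the outer phenyl ring leaves the maximal response where it was: the steps read a number 1.8 percentage points lower from compound 3 to compound 4 (within the scatter) and a number 0.2 percentage points lower from compound 2 to compound 4 (within the scatter) and also a number 2.3 percentage points lower from compound 1 to compound 4 (within the scatter) for this exchange. The 3,4-dichlorophenyl group on this oxygen therefore joins the 2-chlorophenyl, 4-methylphenyl and 2-methylphenyl groups, with all these compounds within the scatter of one another. No measurement shown here bears on this result.

Still open, going by these compounds, is whether an amine or a carboxylic acid on this outer ring would move the response beyond the scatter.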